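The compounds below may be only part of what the source reports. "The series", "measured", "known", "first", "only" and "open" are said of these compounds alone.

Compound 1 `C=C(Br)C(=O)Nc1ccc(C(=O)/C=C/c2cc(OC)cc(OC)c2)cc1` and compound 2 `C=C(Br)C(=O)Nc1ccc(C(=O)/C=C/c2cc(OC)c(OC)c(OC)c2)cc1` share one core. In a functional assay on L1210 cells (Mus musculus) for antiproliferative activity, with a stated time of 48 h (a higher number here means a weaker inhibitor, a lower number a stronger inhibitor), compound 1 gives 2700 nM, and compound 2 gives 1500 nM. The change between them is methoxy in place of hydrogen on an aromatic carbon, and the step it made is a 1.8-fold lower number from compound 1 to compound 2 (0.26 log units; within the scatter). Compound 3 `COc1ccccc1/C=C/C(=O)c1ccc(N)cc1` is built on a different core; the difference between the two cores is not broken down here. In this assay compound 3 gives 12000 nM, a weaker result than either compound 1 or compound 2.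

Compound 4 `COc1cccc(/C=C/C(=O)c2ccc(N)cc2)c1OC` has not been measured yet. It differs from compound 3 by methoxy in place of hydrogen on an aromatic carbon. Within the data shown here, this is the same kind of change as the one from compound 1 to compound 2, though the place is not the same: in compound 2 the entering group is ortho to two methoxy groups and para to a large group, whereas in compound 4 it is ortho to a methoxy group and meta to a large group. Because the earlier step of a 1.8-fold lower number from compound 1 to compound 2 (0.26 log units; within the scatter) stayed within the scatter, the step of a 1.5-fold lower number from compound 3 to compound 4 (0.18 log units; within the scatter) is expected to be small as well. Compound 4 is therefore estimated at 8000 nM in this assay, most likely between 3000 nM and 20000 nM.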

Compound 4, half-maximal inhibitory concentration: 13000 nM
Beside the measured number, compound 4's estimate is 1.6-fold (0.21 log units) below it, and the stated range covers the measured number.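

Putting methoxy in place of hydrogen on an aromatic carbon gives a 1.1-fold higher number from compound 3 to compound 4 (0.03 log units; within the scatter) in this assay. The same change on the core of compound 1 also stayed small, and the two steps agree: the same change on two cores in this assay, a 1.8-fold lower number (0.26 log units; within the scatter) from compound 1 to compound 2 and a 1.1-fold higher number (0.03 log units; within the scatter) from compound 3 to compound 4, 2.0-fold (0.29 log units) apart, within the scatter of two such steps

Among these compounds, this agreement suggests that, for these two pairs, the change carries from one core to the other as a step too small to separate from the scatter, but it rests on only two pairs, with the methoxy entering at a different place in each, and it does not show that the two cores would respond alike to a change with a larger effect. The compounds shown leave open what the same change would do at the same place on both cores, or at other places on the ring. They also leave open whether a different group in place of this methoxy, such as a hydroxyl group, a carboxylic acid or a longer alkoxy chain, would give a step beyond the scatter.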